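This account rests on a few compounds, and the source may have more. Where it says the series, first, only, none or still open, it means among the compounds named here.

Among the compounds with values here, compound 2 `N#CC1=C(N)Oc2c(N)cc3nc4ccccc4nc3c2C12C(=O)N(Cc1cnnn1-c1ccccc1Br)c1ccccc12` carries the only number in an ADME assay on HUVEC cells (Homo sapiens) for antiproliferative activity, read by MTT assay, with a stated time of 48 h; on this read-out higher numbers stand for weaker inhibition and lower numbers for stronger inhibition: compound 2 gives 34200 nM. Compound 1 `N#CC1=C(N)Oc2c(c3nc4ccccc4nc3c3ccccc23)C12C(=O)N(Cc1cnnn1-c1cccc(Cl)c1)c1ccccc12` reaches the assay limit, (the limit of > 50000 nM in this assay, at which 1 of the 2 values shown sits), and compound 1 gives > 50000 nM as a limit rather than a number. Compound 3 `N#CC1=C(N)Oc2c(N)cc3nc4ccccc4nc3c2C12C(=O)N(Cc1cnnn1-c1ccc(F)c(Cl)c1)c1ccccc12` differs from compound 2 in one place, (3-chloro-4-fluorophenyl in place of 2-bromophenyl on an aromatic nitrogen). Within the data shown here, no step between two measured compounds exists to compare with this change, so no direction is expected beyond the usual scatter, and the step of a 1.0-fold higher number from compound 2 to compound 3 (0.01 log units; within the scatter) is expected to stay within it. Compound 3 is estimated at 35000 nM, with a range from 15000 nM to 80000 nM.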

Compound 3, half-maximal inhibitory concentration: > 50000 nM
Compound 3 was reported as a limit; the forecaster's own chance of this, stated with the estimate: 40%; middle value at least 1.4-fold (0.15 log units) away from the limit.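

In this assay, this position on the aromatic nitrogen now has its first direct comparison: 3-chloro-4-fluorophenyl in place of 2-bromophenyl gives an at least 1.4-fold higher number from compound 2 to compound 3 (0.16 log units; that floor lies within the scatter). The value of compound 3 is a limit, not a number, and the series gathers at it: the limit of > 50000 nM in this assay, at which 2 of the 3 values shown sit. From the compounds shown here alone, the change therefore brings no stronger inhibition, but its true size remains unknown.

Still open, going by these compounds, is how far the number for compound 3 lies from compound 2. Also open, on these data alone, is whether an unsubstituted phenyl or an aminophenyl at this position would give a measurable value.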